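Adding a Second Chloro to the Benzyl Ring

This account rests on a few compounds, and the source may have more. Where it says the series, first, only, none or still open, it means among the compounds named here.

Compound 1, `Cc1ccc(NC(=S)NC(=O)c2ccc(OCc3cccc(Cl)c3Cl)cc2)cc1-c1nc2ccccc2[nH]1`: in a functional assay on MGC-803 cells (Homo sapiens) for inhibition, read by MTT assay, with a stated time of 48 h (on this read-out higher numbers stand for weaker inhibition and lower numbers for stronger inhibition), compound 1 gives > 100000 nM, which is a limit of the assay and not a number.
Compound 2, `Cc1ccc(NC(=O)NC(=O)c2ccc(OCc3cccc(Cl)c3)cc2)cc1-c1nc2ccccc2[nH]1`: in this assay compound 2 gives 20800 nM.
Compound 3, `Cc1ccc(NC(=O)NC(=O)c2ccc(OCc3ccc(Cl)c(Cl)c3)cc2)cc1-c1nc2ccccc2[nH]1`: not yet measured.

Among the compounds with values here, compound 2 holds the only real number recorded so far in this assay. Within the data shown here, compound 1 sits at the limit of > 100000 nM in this assay, at which 1 of the 2 values shown sits, so no step between the two measured compounds can be sized, and compound 1 also differs from compound 2 in more than one place, so nothing can be said about the effect of any single change.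

Compound 3 follows compound 2 through one change: chloro in place of hydrogen on an aromatic carbon. Among the measured compounds shown here, with no measured step to lean on, the only guide is the size of change that such a small addition usually brings. The step expected from compound 2 to compound 3 is a 1.4-fold lower number from compound 2 to compound 3 (0.14 log units; within the scatter), which is about the scatter of repeated measurements, with no firm direction.

Compound 3 is estimated at 15000 nM in this assay, with a range from 5000 nM to 45000 nM.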

Compound 3, half-maximal inhibitory concentration: 6080 nM
For compound 3 the middle estimate is 2.5-fold (0.39 log units) above the measured one, and the stated range covers the measured number.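

Within the data shown here, this is the first change in a single place that can be sized: in this assay, chloro in place of hydrogen on the aromatic carbon ortho to the existing chloro group, which turns 3-chlorobenzyl into 3,4-dichlorobenzyl, gives a 3.4-fold lower number from compound 2 to compound 3 (0.53 log units; beyond the scatter). Lower numbers stand for stronger inhibition here, so one added chlorine atom on this ring, with no hydrogen-bond donors or acceptors and no net charge, strengthens inhibition by a modest amount that still exceeds the usual scatter of repeated measurements. Nothing in the data shown speaks to why this added chloro moves the number.

The compounds shown leave open whether the gain belongs to chloro itself or to any small group on this carbon, a question that fluoro, methyl or methoxy at the same place would help to answer. They also leave open whether the new chloro would give a similar step on its own, with the first chloro group replaced by hydrogen, since a single step cannot show whether the two chloro groups depend on each other.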